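A few compounds are considered here, and "the series" means these few. Any claim that something is new, unique, unknown or untested is made for them only; others in the source may bear on it.

- compound 1 `Cc1cc(Cl)ccc1-c1ccc(N2CCC(O)CC2)nn1` at 10 mg/kg
- compound 2 `O=C1CCN(c2ccc(-c3ccccc3Cl)nn2)CC1` at 40 mg/kg

Both values come from a functional assay on the whole organism with Mus musculus as the target, in the maximal electroshock model; a higher number here means that more compound is needed for the effect, a lower number that less compound is needed. Compound 2 has the higher number of the two, and its gap to compound 1 lies beyond the scatter. Among the compounds with values here, these two differ in more than one place, so no single-change step is available. Compound 3 `O=C1CCN(c2ccc(-c3ccc(Cl)cc3Cl)nn2)CC1` is compound 2 with chloro in place of hydrogen on an aromatic carbon, meta to a chloro group and para to a large group (chloro in place of hydrogen on an aromatic carbon). Compound 1 at 10 mg/kg also carries a chloro group, which gives weak support for expecting a lower number. The expected move is modest, a 2.0-fold lower number from compound 2 to compound 3 (0.30 log units; within the scatter) as an estimate, and may stay within the scatter. Compound 3 is expected at 20 mg/kg (estimated range 8 mg/kg to 50 mg/kg).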

Compound 3, dose for half-maximal effect: 5 mg/kg
Estimate against measurement, compound 3: 4.0-fold (0.60 log units) above, and the stated range ends above it.
By their numbers in this assay, from the lowest: compounds 3 and 1 (each within the scatter of the next); then compound 2.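

In this assay, within the data shown here, chloro in place of hydrogen on an aromatic carbon gives an 8.0-fold lower number from compound 2 to compound 3 (0.90 log units; beyond the scatter) and supplies the first single-change step. This place, meta to a chloro group and para to a large group, therefore accepts a chloro group, and the number falls beyond the scatter. Nothing measured here accounts for the size of this step.

Whether the step is particular to chloro remains open, since fluoro, bromo, methyl and methoxy at this place do not appear among the compounds shown. Also open, as far as these compounds go, is whether the same step holds with a hydroxyl group in place of the carbonyl.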